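Compound 3 Without the Fluoro Group

A few compounds are considered here, and "the series" means these few. Any claim that something is new, unique, unknown or untested is made for them only; others in the source may bear on it.

In a functional assay on HeLa cells (Homo sapiens) for inhibition (on this read-out lower numbers stand for stronger inhibition of growth and higher numbers for weaker inhibition of growth), compound 2 `O=C(CN1CCN(c2ccccc2F)CC1)Nc1ccc(-c2nc3ccccc3s2)cc1` gives 200 nM and stands level with compound 1 `Cc1ccc(N2CCN(CC(=O)Nc3ccc(-c4nc5ccccc5s4)cc3)CC2)cc1` at 200 nM on this read-out. The change to compound 3 `O=C(CN1CCN(c2ccccc2)CC1)Nc1ccc(-c2nc3ccccc3s2)cc1` is hydrogen in place of fluoro on an aromatic carbon and puts hydrogen in place of fluoro on an aromatic carbon. For the measured compounds named here, the only measured step that bears on it is no change at the digits printed from compound 1 to compound 2 (within the scatter) with 2-fluorophenyl in place of 4-methylphenyl. No step beyond the scatter is therefore expected in this assay for this change. The estimated step is no change at the digits printed from compound 2 to compound 3 (within the scatter) and has no firmer basis than that one comparison. Compound 3 is expected at 200 nM with an estimated range from 90 nM to 450 nM in this assay for now.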

Compound 3, concentration for 50% growth inhibition: 200 nM
For compound 3 middle estimate and measured number coincide at the digits printed, and the stated range covers the measured number.
By their numbers in this assay, from the lowest: compounds 1, 2 and 3 (each within the scatter of the next).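

In this assay the bare phenyl group gives no change at the digits printed from compound 2 to compound 3 (within the scatter) and no change at the digits printed from compound 1 to compound 3 (within the scatter) so neither the fluoro group nor the methyl group is required for this level of growth inhibition among these three compounds. The ring now reads the same with hydrogen as with either substituent, which the earlier pair alone could not show. No measurement available here gives a reason for this result.

The compounds shown leave open whether a carboxylic acid, an amine or a longer chain on this aromatic ring would also leave the number level.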